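The compounds below may be only part of what the source reports. "The series", "measured", "known", "first", "only" and "open" are said of these compounds alone.

Compound 1 `O=C(c1cc(Cl)cc(Cl)c1)N1CCn2nc(-c3ccccn3)cc2C1`: 270 nM
Compound 2 `Cc1cccnc1-c1cc2n(n1)CCN(C(=O)c1ccccc1)C2`: > 10000 nM

In a functional assay on HEK293 cells for negative allosteric modulation of metabotropic glutamate receptor 5 (Homo sapiens), read by calcium flux, with a stated time of 20 min (on this read-out lower numbers stand for stronger inhibition and higher numbers for weaker inhibition), compound 1 gives 270 nM, a clear inhibitory concentration. Compound 2 gives > 10000 nM, which is a limit of the assay and not a number. As far as these compounds go, compound 2 thus stands at the limit of > 10000 nM in this assay, at which 1 of the 2 values shown sits, and how far beyond that limit it lies stays unknown. For the measured compounds named here, the two compounds differ in two places, so the two values show only that compound 1 is measurable and compound 2 is not.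

Compound 3 `O=C(c1ccccc1)N1CCn2nc(-c3ccc(F)cn3)cc2C1` has not yet been measured. It departs from compound 2 by 5-fluoropyridin-2-yl in place of 3-methylpyridin-2-yl on an aromatic carbon, while the rest of the molecule stays as in compound 2. Going by the values given here, no measured pair covers this exchange, so the expectation rests on compound 1 being active at 270 nM. For compound 2 only a limit of the assay is known. The step from compound 2 to compound 3 is expected to be an at least 6.6-fold lower number from compound 2 to compound 3 (0.82 log units; beyond the scatter), toward stronger inhibition and into the measurable range. Compound 3 is therefore estimated at 1500 nM, within a range from 300 nM to 8000 nM.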

Compound 3, half-maximal inhibitory concentration: 164 nM
The estimate for compound 3 lay 9.1-fold (0.96 log units) above the measured number; the whole stated range lies above it.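

In this assay, 5-fluoropyridin-2-yl in place of 3-methylpyridin-2-yl on this aromatic carbon gives an at least 60-fold lower number from compound 2 to compound 3 (1.78 log units; beyond the scatter). The two earlier compounds differed in two places, so their gap could not be tied to either one, whereas here the rest of the molecule stays the same and this single exchange is enough to bring the series from the limit of the assay into the measurable range. For compound 2, > 10000 nM is a limit of the assay and not a number, so the step has a known lower bound but no known full size: the limit of > 10000 nM in this assay, at which 1 of the 3 values shown sits.

The exchange takes away a methyl group and brings in a fluorine in one move, and the compounds shown do not separate these two changes, so it stays open how much of the step belongs to each. Also open, as far as these compounds go, is how a phenyl ring or a 5-chloropyridin-2-yl group would read on this same carbon, with the rest of the molecule kept as in compound 3.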